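Working notes: trifluoromethyl to methoxy swap

The source may report more compounds than this note shows. Statements on the series, on what has been measured and on what is new or still open speak of the compounds shown alone.

Measured so far:
compound 1 `C/C(=C\c1cc(-c2ccc(C#N)cc2)cs1)C(N)=O` — 250 nM
compound 2 `C/C(=C\c1cc(-c2ccc(C(F)(F)F)cc2)cs1)C(N)=O` — > 50000 nM

In a functional assay on HeLa cells (Homo sapiens) for cytotoxicity, read by CCK-8 assay, with a stated time of 24 h (on this read-out higher numbers stand for weaker inhibition and lower numbers for stronger inhibition), compound 1 gives 250 nM. Compound 2 gives only a limit, > 50000 nM, which is the limit of > 50000 nM in this assay, at which 1 of the 2 values shown sits. Compound 2 therefore stands as the weaker of the two entries, its number unknown beyond that limit. Compound 3 `COc1ccc(-c2csc(/C=C(\C)C(N)=O)c2)cc1` differs from compound 2 by methoxy in place of trifluoromethyl on an aromatic carbon. Going by the values given here, the single measured step, an at least 200-fold higher number from compound 1 to compound 2 (2.30 log units; beyond the scatter), concerns cyano against trifluoromethyl and so bears only indirectly on a methoxy exchange. With compound 2 at a limit, a step is expected toward a lower number, an at least 5.0-fold lower number from compound 2 to compound 3 (0.69 log units; beyond the scatter), though it may remain at the limit. Compound 3 is estimated at 10000 nM, between 500 nM and 50000 nM.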

Compound 3, half-maximal inhibitory concentration: > 50000 nM
Compound 3 ended at the assay's limit; the forecaster's own chance of this, stated with the estimate: 45%; at least 5.0-fold (0.69 log units) between middle value and limit.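

In this assay, the cyano of compound 1 now has a second replacement at this aromatic carbon, para to a large group, and methoxy gives an at least 200-fold higher number from compound 1 to compound 3 (2.30 log units; beyond the scatter). Compound 3 reads as a limit, as compound 2 does, so the step between them cannot be read: the limit of > 50000 nM in this assay, at which 2 of the 3 values shown sit.

Going by these compounds, how far either compound lies beyond that limit stays open. On these data alone, it also stays open whether any other group at this place, such as an amine or a carboxylic acid, would give a measurable number as cyano does.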